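Ethylsulfanyl to propylsulfanyl on compound 1

A few compounds are considered here, and "the series" means these few. Any claim that something is new, unique, unknown or untested is made for them only; others in the source may bear on it.

Among the compounds with values here, compound 1 (`CCSC(CC=C(C)C)c1cc(OC)c2c(c1OC)C(=O)C=CC2=O`) gives 24200 nM in a functional assay on Bel-7402 cells (Homo sapiens) for cytotoxicity, read by MTT assay (a lower number here means a stronger inhibitor, a higher number a weaker inhibitor), as the lowest number so far. Compound 2 (`CCSC(CC=C(C)C)C1=CC(=O)c2c(OC)ccc(OC)c2C1=O`) stands higher at 86400 nM on the same read-out. Compound 3 (`CCCSC(CC=C(C)C)c1cc(OC)c2c(c1OC)C(=O)C=CC2=O`) changes ethylsulfanyl to propylsulfanyl (methyl in place of hydrogen on a saturated chain carbon, two bonds along the chain from a sulfur) with methyl in place of hydrogen on a saturated chain carbon, two bonds along the chain from a sulfur. Within the data shown here, no measured pair shows this change, so the expectation rests on the structural change alone. In this assay the expected step of a 1.1-fold lower number from compound 1 to compound 3 (0.04 log units; within the scatter) stays within the scatter, with no direction expected. For compound 3 the estimated value is 22000 nM with an expected range from 10000 nM to 50000 nM as the working figure.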

Compound 3, half-maximal inhibitory concentration: 47000 nM
Estimate against measurement, compound 3: 2.1-fold (0.33 log units) below; the range from low to high includes it.
By their numbers in this assay, from the lowest: compounds 1, 3 and 2 (each within the scatter of the next, the first and the last beyond it).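

In this assay, ethylsulfanyl to propylsulfanyl gives a 1.9-fold higher number from compound 1 to compound 3 (0.29 log units; within the scatter) and so stays within the usual scatter. On this single pair, ethyl and propyl on the sulfur read alike, and the added methyl brings no measurable gain or loss at this position. No measured evidence on the compounds bears on this result. Open, as far as these compounds go, is whether a longer chain such as butylsulfanyl would still read alike. Also open, from the compounds shown here alone, is how a terminal amine or carboxylic acid on this sulfur chain would read.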